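Methoxy for hydroxyl on the cyclohexyl amine

A few compounds are considered here, and "the series" means these few. Any claim that something is new, unique, unknown or untested is made for them only; others in the source may bear on it.

Compound 1 `N#Cc1cnc(NCc2cnccc2C(F)(F)F)cc1N[C@H]1C[C@@H](O)C1` in an assay on isolated protein for inhibition of protein kinase C delta type (Homo sapiens), read by TR-FRET, with a stated time of 2 h (on this read-out higher numbers stand for weaker inhibition and lower numbers for stronger inhibition), gives a limit of > 10000 nM.
Compound 2 `N#Cc1cnc(NCc2cnccc2C(F)(F)F)cc1N[C@H]1CC[C@@H](O)CC1` gives 4500 nM.
Compound 3 `N#Cc1cnc(NCc2cnccc2C(F)(F)F)cc1N[C@H]1CC[C@H](O)CC1` gives 6500 nM.

Compound 3 holds the higher of the two numbers, with compound 2 nearest at a step of a 1.4-fold higher number from compound 2 to compound 3 (0.16 log units; within the scatter). Compound 4 `CO[C@H]1CC[C@@H](Nc2cc(NCc3cnccc3C(F)(F)F)ncc2C#N)CC1` differs from compound 3 by 4-methoxycyclohexyl in place of 4-hydroxycyclohexyl on a nitrogen on an aromatic ring. For the measured compounds named here, none of the measured steps touches the hydroxyl: an at least 2.2-fold lower number from compound 1 to compound 2 (0.34 log units; beyond the scatter) and an at least 1.5-fold lower number from compound 1 to compound 3 (0.18 log units; that floor lies within the scatter) change ring size, and a 1.4-fold higher number from compound 2 to compound 3 (0.16 log units; within the scatter) only configuration, as the fact that compounds 2 and 3 differ only in the configuration as drawn shows. Going by the values given here, no step is therefore expected beyond the scatter, and compound 4 is estimated at 7000 nM (range 2500 nM to 20000 nM), a step of a 1.1-fold higher number from compound 3 to compound 4 (0.03 log units; within the scatter) being expected.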

Compound 4, half-maximal inhibitory concentration: 5000 nM
The estimate for compound 4 lay 1.4-fold (0.15 log units) above the measured number; the range from low to high includes it.
By their numbers in this assay, from the lowest: compounds 2, 4 and 3 (each within the scatter of the next). At a limit, above all of these: compound 1.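

Compound 4, whose 4-methoxycyclohexyl carries no hydrogen-bond donor, stays within the scatter of both hydroxyl compounds in this assay: a 1.1-fold higher number from compound 2 to compound 4 (0.05 log units; within the scatter) and a 1.3-fold lower number from compound 3 to compound 4 (0.11 log units; within the scatter). Capping the hydroxyl with methyl on this group therefore makes no readable difference here, neither for better nor for worse. The remaining step, an at least 2.0-fold lower number from compound 1 to compound 4 (0.30 log units; that floor lies within the scatter), gives only a floor and cannot be read as a size: the limit of > 10000 nM in this assay, at which 1 of the 4 values shown sits.

As far as these compounds go, whether an amine, a carboxylic acid or a longer ether chain in place of the methoxy group would separate from these numbers stays open.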